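The source may report more compounds than this note shows. Statements on the series, on what has been measured and on what is new or still open speak of the compounds shown alone.

Compound 1 `Cc1ccc(OC[C@H](C)COc2ccc(C(=O)CC(C)(C)C)c(O)c2C)cc1C(=O)O` gives a limit rather than a number in an assay for positive allosteric modulation of metabotropic glutamate receptor 3 (Rattus norvegicus) (a higher number here means that more compound is needed for the effect, a lower number that less compound is needed), namely > 10000 nM (the limit of > 10000 nM in this assay, at which 1 of the 3 values shown sits). Compound 2 `Cc1cc(C(=O)O)ccc1OC[C@H](C)COc1ccc(C(=O)CC(C)(C)C)c(O)c1C` gives 1520 nM in this assay. Compound 3 `Cc1c(OC[C@@H](C)COc2ccc(C(=O)O)c(F)c2)ccc(C(=O)CC(C)(C)C)c1O` gives 1090 nM in this assay, the lowest of the two numbers obtained, though its step of a 1.4-fold lower number from compound 2 to compound 3 (0.14 log units; within the scatter) lies within the scatter, so the two compounds cannot be ordered. Compound 4 `Cc1c(OC[C@@H](C)COc2ccc(C(=O)O)c(Cl)c2)ccc(C(=O)CC(C)(C)C)c1O` differs from compound 3 by chloro in place of fluoro on an aromatic carbon. Going by the values given here, no measured step exchanges one halogen for another; the only step at this end of the molecule that yields a number, a 1.4-fold lower number from compound 2 to compound 3 (0.14 log units; within the scatter), is small. Steps an at least 6.5-fold lower number from compound 1 to compound 2 (0.81 log units; beyond the scatter) and an at least 9.1-fold lower number from compound 1 to compound 3 (0.96 log units; beyond the scatter) move the carboxy group itself and rest on a limit, so they say little about a halogen swap beside an unchanged carboxy group. The step from compound 3 to compound 4 in this assay is therefore expected to stay within the scatter, a 1.2-fold lower number from compound 3 to compound 4 (0.08 log units; within the scatter). Compound 4 is estimated at 900 nM in this assay, between 350 nM and 2500 nM.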

Compound 4, half-maximal effective concentration: 860 nM
Beside the measured number, compound 4's estimate is 1.0-fold (0.02 log units) above it; the measured number falls inside the stated range.
By their numbers in this assay, from the lowest: compounds 4, 3 and 2 (each within the scatter of the next). At a limit, above all of these: compound 1.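

Chloro in place of fluoro on an aromatic carbon ortho to a carboxy group gives a 1.3-fold lower number from compound 3 to compound 4 (0.10 log units; within the scatter) in this assay, and 4-carboxy-3-chlorophenyl in place of 4-carboxy-2-methylphenyl gives a 1.8-fold lower number from compound 2 to compound 4 (0.25 log units; within the scatter), so at this position the two halogens cannot be told apart, and neither can these two groups. Of the new steps, only an at least 11-fold lower number from compound 1 to compound 4 (1.06 log units; beyond the scatter) lies beyond the scatter, and it starts from a limit rather than a number. Compound 1 remains at that limit: the limit of > 10000 nM in this assay, at which 1 of the 4 values shown sits.

From the compounds shown here alone, whether a bromo, a methyl or a methoxy group at this position would read differently from chloro and fluoro stays open. So does whether a tetrazole or a primary amide could stand in place of the carboxy group with the halogen kept.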